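Nitrooxyphenyl in Place of Dimethoxyphenyl on a Hydrazone Carbon

A few compounds are considered here, and "the series" means these few. Any claim that something is new, unique, unknown or untested is made for them only; others in the source may bear on it.

Of the compounds shown here, three built on one shared core have been measured in a functional assay on MKN-45 cells (Homo sapiens) for cytotoxicity, read by MTT assay, with a stated time of 72 h; on this read-out higher numbers stand for weaker inhibition and lower numbers for stronger inhibition. Compound 1 `CN(C)CCn1cnnc1-c1cc(Oc2ccc(NC(=O)N/N=C/c3cc(C(C)(C)C)cc(C(C)(C)C)c3O)cc2F)ccn1` gives 3300 nM. Compound 2 `COc1ccc(OC)c(/C=N/NC(=O)Nc2ccc(Oc3ccnc(-c4nncn4CCN(C)C)c3)c(F)c2)c1` gives 1510 nM, and compound 3 `COc1ccc(/C=N/NC(=O)Nc2ccc(Oc3ccnc(-c4nncn4CCN(C)C)c3)c(F)c2)c(OC)c1` gives 1680 nM. Compound 3 thus holds the second highest of the three numbers; compound 2 is its nearest neighbour and compound 1 its furthest, yet both gaps lie within the scatter. Among the compounds with values here, the only one-place step among the measured compounds, a 1.1-fold higher number from compound 2 to compound 3 (0.05 log units; within the scatter), exchanges one dimethoxy pattern for the other and leaves the read-out essentially where it was.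

Compound 4 `CN(C)CCn1cnnc1-c1cc(Oc2ccc(NC(=O)N/N=C/c3ccccc3O[N+](=O)[O-])cc2F)ccn1` has not yet been measured. It differs from compound 3 by 2-(nitrooxy)phenyl in place of 2,4-dimethoxyphenyl on a carbon with a double bond to nitrogen. Within the data shown here, no measured step replaces this aryl group with a substituent of a different kind. What is available is a 1.1-fold higher number from compound 2 to compound 3 (0.05 log units; within the scatter), which shows that rearranging the same two methoxy groups changes nothing beyond the scatter, and the observation that compound 1, carrying a quite different ring on the same carbon, also sits within the scatter of compound 3. The data therefore give no basis for expecting a shift beyond the scatter in this assay. Compound 4 is estimated at 2000 nM, within a range from 700 nM to 6000 nM. The expected step of a 1.2-fold higher number from compound 3 to compound 4 (0.08 log units; within the scatter) is accordingly small, in no firm direction.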

Compound 4, half-maximal inhibitory concentration: 1020 nM
Compound 4: the middle estimate sits 2.0-fold (0.29 log units) above what was measured; low and high end bracket the measured number.
By their numbers in this assay, from the lowest: compounds 4, 2, 3 and 1 (each within the scatter of the next, the first and the last beyond it).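

In this assay, placing 2-(nitrooxy)phenyl on the carbon with a double bond to nitrogen gives a 1.6-fold lower number from compound 3 to compound 4 (0.22 log units; within the scatter) and, measured against the other dimethoxy pattern, a 1.5-fold lower number from compound 2 to compound 4 (0.17 log units; within the scatter). Both steps lie within the scatter, so a ring carrying a single nitrooxy group and no methoxy group remains level with both dimethoxyphenyl compounds, a replacement of a different kind from the rearrangement of two methoxy groups seen earlier. The new value also gives the set its first pair beyond the scatter of each other, with compound 1 at 3300 nM and compound 4 at 1020 nM, although each compound in the series remains within the scatter of its neighbour.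

The compounds shown offer no measurement that explains these numbers. They also leave open whether the nitrooxy group itself contributes anything at this position, which 2-hydroxyphenyl or unsubstituted phenyl on the same carbon could test, and whether an amine or a carboxylic acid on this ring would keep the read-out within the same range.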